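Swapping the nitrile for a methyl on the benzyl arm

The source may report more compounds than this note shows. Statements on the series, on what has been measured and on what is new or still open speak of the compounds shown alone.

Measured so far:
compound 1, `COC(=O)[C@H](CCSC)NC(=O)c1ccc(NCc2cncn2Cc2cccc(C#N)c2)cc1-c1ccccc1`, in a functional assay on NIH3T3 cells (Mus musculus); on this read-out higher numbers stand for an effect only at larger amounts of compound and lower numbers for an effect already at smaller amounts: > 10 uM
compound 2, `COC(=O)[C@H](CCSC)NC(=O)c1ccc(NCc2cncn2Cc2ccc(C#N)cc2)cc1-c1ccccc1`, in this assay: > 10 uM

Compound 1 in this assay reaches only a limit of the assay, > 10 uM. Compound 2 in this assay likewise reaches only a limit, > 10 uM. The change between them, a step that the two limits leave unreadable from compound 1 to compound 2, therefore cannot be read as a size. Both values sit at the limit of > 10 uM in this assay, at which 2 of the 2 values shown sit, so compound 2 stands at the edge of what the assay can report.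

Compound 3, `COC(=O)[C@H](CCSC)NC(=O)c1ccc(NCc2cncn2Cc2cccc(C)c2)cc1-c1ccccc1`, differs from compound 2 by 3-methylphenyl in place of 4-cyanophenyl on a saturated chain carbon bound to an aromatic nitrogen. Going by the values given here, no measured step bears on this change beyond the unreadable one, so no shift in this assay can be expected with confidence. Compound 3 is therefore expected to give about 15 uM in this assay, within a range of 4 uM to 60 uM. The expected step is a step that the limit leaves unreadable from compound 2 to compound 3, most likely again a limit rather than a number.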

Compound 3, concentration for half-maximal effect: > 10 uM
Compound 3: a limit, no number (the forecaster's own chance of this, stated with the estimate: 70%); the middle value is on the limit's open side.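

No step among compound 1, compound 2 and compound 3 can be read as a size, because each result is only a limit of the assay: the limit of > 10 uM in this assay, at which 3 of the 3 values shown sit.

On these data alone, what stays open is whether these three compounds differ at all in this assay, and at what concentration each would reach its half-maximal effect.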